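Adding a Second Chloro Group to Compound 3

The source may report more compounds than this note shows. Statements on the series, on what has been measured and on what is new or still open speak of the compounds shown alone.

The measured compounds:
- compound 1 `COc1ccccc1/C=c1/[nH]c(=O)/c(=C\c2cccc(Cl)c2Cl)[nH]c1=O`, in a functional assay on HeLa cells (Homo sapiens) for cytotoxicity, read by CCK-8 assay, with a stated time of 72 h (on this read-out lower numbers stand for stronger inhibition and higher numbers for weaker inhibition), compound 1 is reported as "not active" (no number reported)
- compound 2 `C=CCn1c(=O)/c(=C\c2cccc(F)c2)[nH]c(=O)/c1=C\c1ccccc1OC`, compound 2 gives 9100 nM
- compound 3 `C=CCn1c(=O)/c(=C\c2ccccc2Cl)[nH]c(=O)/c1=C\c1ccccc1OC`, compound 3 gives 5100 nM

Among the measured compounds shown here, only two compounds carry a number here. For the measured compounds named here, compound 3 has the lowest of the two, but its only neighbour is compound 2, and the step of a 1.8-fold lower number from compound 2 to compound 3 (0.25 log units; within the scatter) lies within the scatter, so compound 3 and compound 2 cannot be ordered. Compound 1, which carries the same aryl group that compound 4 will carry but lacks the allyl chain, was reported without a number.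

Compound 4 `C=CCn1c(=O)/c(=C\c2cccc(Cl)c2Cl)[nH]c(=O)/c1=C\c1ccccc1OC` differs from compound 3 by chloro in place of hydrogen on an aromatic carbon. Going by the values given here, no measured step matches this change, so there is no basis for expecting a shift beyond the scatter. The reported inactivity of compound 1 raises some doubt, but it differs in a second place as well. Compound 4 is therefore expected to sit near compound 3, with the step of a 1.1-fold lower number from compound 3 to compound 4 (0.05 log units; within the scatter) counted as an estimate, giving an expected value of 4500 nM within the range 1500 nM to 15000 nM.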

Compound 4, half-maximal inhibitory concentration: 1600 nM
Estimate against measurement, compound 4: 2.8-fold (0.45 log units) above; the measured number falls inside the stated range.
By their numbers in this assay, from the lowest: compound 4; then compounds 3 and 2 (each within the scatter of the next).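

Adding one chloro group to the aromatic ring, ortho to a chloro group, gives a 3.2-fold lower number from compound 3 to compound 4 (0.50 log units; beyond the scatter) in this assay and is the first change here to clear the scatter. Replacing 3-fluorophenyl with 2,3-dichlorophenyl gives a 5.7-fold lower number from compound 2 to compound 4 (0.75 log units; beyond the scatter) and confirms that compound 4 stands apart from both of its neighbours. Nothing available explains why this added chloro group lowers the number.

As far as these compounds go, whether a bromo group or an amine in the same place would do the same remains open. Compound 1 carries the same 2,3-dichlorophenyl group without the allyl chain and is reported as "not active" (no number reported) in this assay so the part played by that chain, or by a longer chain in its place, also stays unsettled.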